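Working notes: furan-2-yl for thiophen-2-yl, compound 4

This account rests on a few compounds, and the source may have more. Where it says the series, first, only, none or still open, it means among the compounds named here.

Measured so far:
compound 1 `Oc1ccc(-c2cc(-c3ccc(Cl)cc3)nc(-c3cccs3)c2)cc1` — in an ADME assay on HEK293 cells (Homo sapiens) for cytotoxicity, read by CCK-8 assay and cell counting, with a stated time of 2 days (a lower number here means a stronger inhibitor, a higher number a weaker inhibitor), compound 1 gives 4520 nM
compound 2 `Oc1ccc(-c2cc(-c3cccc(Cl)c3)nc(-c3cccs3)c2)cc1` — in this assay compound 2 gives 2720 nM
compound 3 `Oc1cccc(-c2cc(-c3cccc(Cl)c3)nc(-c3cccs3)c2)c1` — in this assay compound 3 gives 3150 nM

Compound 2 holds the lowest of the three numbers in this assay, but the distances to its neighbours are small: a 1.2-fold higher number from compound 2 to compound 3 (0.06 log units; within the scatter) and a 1.7-fold lower number from compound 1 to compound 2 (0.22 log units; within the scatter), both within the scatter. The three measured compounds are therefore not separable on these data, and no order among them should be read.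

Compound 4 `Oc1ccc(-c2cc(-c3cccc(Cl)c3)nc(-c3ccco3)c2)cc1` has not yet been measured. It differs from compound 2 in a single place: furan-2-yl in place of thiophen-2-yl on an aromatic carbon. Among the measured compounds shown here, no measured step touches this five-membered ring. The two steps that exist move a substituent around a six-membered ring, from compound 1 to compound 2 and from compound 2 to compound 3, and each stayed within the scatter. For the measured compounds named here, the only guide for compound 4 is thus the narrow spread of the whole series, not a matched precedent for the exchange itself.

On that basis a step of a 1.0-fold higher number from compound 2 to compound 4 (0.01 log units; within the scatter) is expected for compound 4, i.e. nothing beyond the scatter, with a wide band to allow for an untested change. Compound 4 is estimated at 2800 nM, expected to fall between 1200 nM and 6500 nM.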

Compound 4, half-maximal inhibitory concentration: 2880 nM
Beside the measured number, compound 4's estimate is 1.0-fold (0.01 log units) below it, within the range that was stated.
By their numbers in this assay, from the lowest: compounds 2, 4, 3 and 1 (each within the scatter of the next).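

Exchanging thiophen-2-yl for furan-2-yl at this position, next to the ring nitrogen, gives a 1.1-fold higher number from compound 2 to compound 4 (0.02 log units; within the scatter) in this assay, so this change of ring sulfur to ring oxygen leaves the number inside the scatter. Among the compounds shown here, the earlier steps only moved substituents around the six-membered rings bearing the chloro and hydroxy groups; this is the first reading at the five-membered ring itself, and it shows that, at least in the setting of the 3-chlorophenyl and 4-hydroxyphenyl groups, one five-membered aromatic ring with a single hetero atom can stand in for the other without a separable difference. Nothing available accounts for this result or ties it to any property of either ring.

The two rings match in heavy atoms and hydrogen-bond acceptors, so the series says little about how the number responds at this position to a truly different group, such as a basic amine, a carboxylic acid or a longer alkyl chain. Going by these compounds, it also remains open whether the same exchange would read alike with the substituent arrangements of compound 1 or compound 3.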